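Clearance Outlook for a Methylaminomethyl Piperidine Analogue

This account rests on a few compounds, and the source may have more. Where it says the series, first, only, none or still open, it means among the compounds named here.

Compound 1 `CCCCCOC(=O)N1CCN(C(=O)[C@H](CCC(=O)O)NC(=O)c2cc(N3CCC(OCCO)CC3)nc(-c3ccccc3)n2)CC1`: 18 mL/min/kg
Compound 2 `CCCCCOC(=O)N1CCN(C(=O)[C@H](CCC(=O)O)NC(=O)c2nc(-c3ccccc3)cc(N3CCC(CN)CC3)n2)CC1`: 16 mL/min/kg

Of the compounds shown here, two have been measured in an in vivo ADME assay on the whole organism (strain Sprague-Dawley) for pharmacokinetics, with Rattus norvegicus as the target; a lower number here means slower removal, a higher number faster removal of the compound. In this assay compound 1 gives 18 mL/min/kg, the higher of the two numbers, while compound 2 gives 16 mL/min/kg; the gap between them lies within the usual scatter, so no order can be read from it. Compound 3 `CCCCCOC(=O)N1CCN(C(=O)[C@H](CCC(=O)O)NC(=O)c2cc(N3CCC(CNC)CC3)nc(-c3ccccc3)n2)CC1` has not yet been measured. It differs from compound 1 in one place: (methylamino)methyl in place of 2-hydroxyethoxy on a saturated ring carbon. Within the data shown here, no step between measured compounds isolates this change, so any expectation rests on the two values at hand, which sit close together. Compound 3 is therefore expected to show a step of a 1.1-fold lower number from compound 1 to compound 3 (0.02 log units; within the scatter) that stays within the scatter, with no direction beyond it. The clearance of compound 3 in this assay is estimated at 17 mL/min/kg, within a range from 9 mL/min/kg to 32 mL/min/kg.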

Compound 3, clearance: 31 mL/min/kg
Compound 3: middle estimate off by 1.8-fold (0.26 log units), on the low side; low and high end bracket the measured number.
By their numbers in this assay, from the lowest: compounds 2, 1 and 3 (each within the scatter of the next).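

In this assay, the exchange of 2-hydroxyethoxy for (methylamino)methyl on the saturated ring carbon gives a 1.7-fold higher number from compound 1 to compound 3 (0.24 log units; within the scatter), the only step shown that isolates a change at this position. This single pair indicates that swapping this oxygen-bearing chain for this nitrogen-bearing one leaves the clearance within what repeated measurements would scatter, so no direction can be claimed for the change. No measurement at hand offers an explanation for this step.

From the compounds shown here alone, whether a carboxylic acid, a longer chain ending in an amine or a (dimethylamino)methyl group on the same ring carbon would also stay within the scatter of compound 1 remains open. So does whether the same exchange would give a similar step on a different core.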